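From Acetyl to Dimethylamino: an Expected Step

The source may hold more compounds than are shown below. What is called first, only, known or untested is meant among the compounds shown, and "the series" means these compounds.

Measured compounds:
compound 1, `COc1cc(C)cc(-c2c(-c3ccnc(-c4ccc(C(C)=O)cc4)c3)cnn2CC#N)c1`, in a functional assay on UACC-257 cells (Homo sapiens) for inhibition, read by sulforhodamine B assay, with a stated time of 48 h (on this read-out lower numbers stand for stronger inhibition of growth and higher numbers for weaker inhibition of growth), compound 1 gives 5240 nM
compound 2, `COc1cc(C)cc(-c2nn(CC#N)cc2-c2ccc(-c3cccc(C(C)=O)c3)nc2)c1`, in this assay compound 2 gives 3610 nM
compound 3, `Cc1cc(O)cc(-c2nn(CC#N)cc2-c2ccnc(-c3ccc(Oc4ccccc4)cc3)c2)c1`, in this assay compound 3 gives 2380 nM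

Among these three numbers, compound 1 gives the highest one. The number of compound 2 lies within the usual scatter of repeated measurements of that of compound 1, so the two cannot be told apart; the number of compound 3 lies beyond that scatter, on the lower side. No two of these compounds differ in only one place, so none of the three pairs shows a clean single step.

Compound 4, `COc1cc(C)cc(-c2c(-c3ccnc(-c4ccc(N(C)C)cc4)c3)cnn2CC#N)c1`, has not yet been measured. It differs from compound 1 in one place: dimethylamino in place of acetyl on an aromatic carbon. Going by the values given here, nothing among the measured compounds shows what this change does, so the expectation rests on the change being a like-for-like swap of two small groups of the same size on the same aromatic carbon. The step from compound 1 to compound 4 in this assay is estimated at a 1.0-fold lower number from compound 1 to compound 4 (0.02 log units; within the scatter), that is, no change beyond the scatter. Compound 4 is therefore expected to give about 5000 nM, with a range from 1700 nM to 15000 nM.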

Compound 4, concentration for 50% growth inhibition: 35.9 nM
Compound 4: middle estimate off by 140-fold (2.14 log units), on the high side, outside the stated range (below it).
By their numbers in this assay, from the lowest: compound 4; then compounds 3, 2 and 1 (each within the scatter of the next, the first and the last beyond it).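

In this assay, putting dimethylamino in place of acetyl on the aromatic carbon para to a large group gives a 150-fold lower number from compound 1 to compound 4 (2.16 log units; beyond the scatter). This shows that the position is highly sensitive to which group sits there, even though acetyl and dimethylamino have the same count of heavy atoms and the same count of hydrogen-bond acceptors. The earlier compounds could not show this, as no two of them differ in only one place, and nothing available here accounts for the size of the step.

Whether this large step is specific to dimethylamino remains open, since the compounds shown include no diethylamino group, unsubstituted amine or morpholine ring on this carbon. It is also unclear whether the same swap would produce a similar step in compound 2, which carries an acetyl group too but has a differently built core.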